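A few compounds are considered here, and "the series" means these few. Any claim that something is new, unique, unknown or untested is made for them only; others in the source may bear on it.

Measured so far:
compound 1 `CCC(=O)NCc1cc(OC)ccc1F` — 2400 nM
compound 2 `COc1ccc(CNC(C)=O)cc1F` — 1510 nM

In an assay on isolated protein for agonist activity at melatonin receptor type 1C (Xenopus laevis), read by spectrophotometry (a higher number here means that more compound is needed for the effect, a lower number that less compound is needed), compound 2 has the lowest of the two numbers; its nearest neighbour is compound 1, whose value sits within the scatter, so no order between them can be claimed. Compound 3 `CCCC(=O)NCc1ccc(OC)c(F)c1` differs from compound 2 by ethyl in place of hydrogen on a saturated chain carbon bound to a carbonyl carbon. Among the compounds with values here, no measured pair shows this change, so its effect is unknown. A step toward a lower number in this assay, of modest size and possibly no more than the scatter, is expected as a 1.9-fold lower number from compound 2 to compound 3 (0.28 log units; within the scatter). Compound 3 is therefore estimated at 800 nM, in the range 250 nM to 2500 nM.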

Compound 3, half-maximal effective concentration: 661 nM
Compound 3: middle estimate off by 1.2-fold (0.08 log units), on the high side, and the stated range covers the measured number.
By their numbers in this assay, from the lowest: compound 3; then compounds 2 and 1 (each within the scatter of the next).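

In this assay, within the data shown here, ethyl in place of hydrogen on a saturated chain carbon bound to a carbonyl carbon gives a 2.3-fold lower number from compound 2 to compound 3 (0.36 log units; beyond the scatter) and is the first single-place change that can be read. This saturated chain carbon therefore tolerates the added ethyl, and the number moves lower rather than higher. No measured data bear on the origin of this step. As far as these compounds go, whether a longer chain such as butyl, or a cyclopropyl ring, would extend the step remains open. Also open, from the compounds shown here alone, is whether the same change holds on the core of compound 1.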